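Adding a methyl to compound 2

The source may report more compounds than this note shows. Statements on the series, on what has been measured and on what is new or still open speak of the compounds shown alone.

Measured in a functional assay on HCT-15 cells (Homo sapiens) for cytotoxicity; on this read-out higher numbers stand for weaker inhibition and lower numbers for stronger inhibition:
- compound 1 `Cc1ccc(-c2cc3ccccc3c(O)n2)cc1`: 42700 nM
- compound 2 `Cc1ccc2c(O)nc(-c3ccccc3)cc2c1`: 5130 nM

Compound 2 holds the lower of the two numbers (5130 nM). Compound 1 gives 42700 nM, and the gap between these two numbers lies outside the scatter. Compound 3 `Cc1ccc2c(O)nc(-c3ccccc3C)cc2c1` differs from compound 2 by methyl in place of hydrogen on an aromatic carbon, ortho to a large group. Among the compounds with values here, no measured pair shows this change. In this assay only a small step toward a higher number, within the scatter, is expected. The expected change is a 1.2-fold higher number from compound 2 to compound 3 (0.07 log units; within the scatter) as an estimate. For compound 3 the estimated value is 6000 nM, with a range from 1800 nM to 20000 nM.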

Compound 3, half-maximal inhibitory concentration: 30900 nM
Estimate against measurement, compound 3: 5.2-fold (0.71 log units) below, outside the stated range (above it).
By their numbers in this assay, from the lowest: compound 2; then compounds 3 and 1 (each within the scatter of the next).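

In this assay, methyl in place of hydrogen on an aromatic carbon, ortho to a large group, gives a 6.0-fold higher number from compound 2 to compound 3 (0.78 log units; beyond the scatter), a modest loss beyond the scatter. Within the data shown here, this is the first single-place change, and it shows that this position does not accept methyl without a loss of inhibition. Nothing available explains the loss.

Going by these compounds, whether a fluorine, a methoxy or an amine in the same place gives a similar loss remains open. So does whether methyl on another carbon of this ring has the same effect.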